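Moving from an oxazole amide to an aminophenyl amide

The source may hold more compounds than are shown below. What is called first, only, known or untested is meant among the compounds shown, and "the series" means these compounds.

Measured so far, in an assay on isolated protein for inhibition of Rho-associated protein kinase 2 (Homo sapiens), read by scintillation counting, radiometric assay and 33P incorporation, with a stated time of 40 min, in the presence of a further agent that is not named here; a higher number here means a weaker inhibitor, a lower number a stronger inhibitor:
compound 1 `CCc1ccc(C(=O)Nc2cccc(NC(=O)COc3ccc4c(=O)ccoc4c3)c2)cc1` gives 24 nM
compound 2 `O=C(COc1ccc2c(=O)ccoc2c1)Nc1cccc(NC(=O)c2ccc(F)cc2)c1` gives 54 nM
compound 3 `CC(C)(C)c1cc(C(=O)Nc2cccc(NC(=O)COc3ccc4c(=O)ccoc4c3)c2)no1` gives 5 nM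

Compound 3 stands with the lowest number of the three, so it is the strongest inhibitor here; the nearest is compound 1, and the step runs as a 4.8-fold lower number from compound 1 to compound 3 (0.68 log units; beyond the scatter), while the step from compound 2 is larger, an 11-fold lower number from compound 2 to compound 3 (1.03 log units; beyond the scatter).

Compound 4 `Nc1ccc(C(=O)Nc2cccc(NC(=O)COc3ccc4c(=O)ccoc4c3)c2)cc1` has not been measured yet. It differs from compound 3 in one place: 4-aminophenyl in place of 5-(tert-butyl)-1,2-oxazol-3-yl on a carbonyl carbon. The two measured steps that bear on this are those that replace a phenyl amide with the oxazole amide, a 4.8-fold lower number from compound 1 to compound 3 (0.68 log units; beyond the scatter) and an 11-fold lower number from compound 2 to compound 3 (1.03 log units; beyond the scatter), both beyond the scatter and both favouring the oxazole. The step of a 2.3-fold higher number from compound 1 to compound 2 (0.35 log units; beyond the scatter) shows that the group on the phenyl ring also matters, though modestly. Going back to a phenyl amide is therefore expected to raise the number, by about an 8.0-fold higher number from compound 3 to compound 4 (0.90 log units; beyond the scatter). Compound 4 is expected at 40 nM, between 12 nM and 130 nM.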

Compound 4, half-maximal inhibitory concentration: 83 nM
Beside the measured number, compound 4's estimate is 2.1-fold (0.32 log units) below it; the range from low to high includes it.
By their numbers in this assay, from the lowest: compound 3; then compound 1; then compounds 2 and 4 (each within the scatter of the next).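

Replacing the 5-(tert-butyl)-1,2-oxazol-3-yl on this carbonyl carbon with 4-aminophenyl gives a large change (a 17-fold higher number from compound 3 to compound 4 (1.22 log units; beyond the scatter)), so a third phenyl amide also falls short of the oxazole amide. Among the phenyl amides, amino in place of fluoro stays within the scatter (a 1.5-fold higher number from compound 2 to compound 4 (0.19 log units; within the scatter)), while amino in place of ethyl goes beyond it (a 3.5-fold higher number from compound 1 to compound 4 (0.54 log units; beyond the scatter)), leaving ethyl as the one group of these three that stands apart from the other two. Nothing available here explains these differences.

Going by these compounds, it remains open whether the advantage of compound 3 lies in the oxazole ring or in its tert-butyl group, a question that a 4-(tert-butyl)phenyl amide would help to settle. On these data alone, it is also open how a methoxy group or a carboxylic acid on the phenyl ring would compare with ethyl.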